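Swapping phenylcarbamoyl for benzyl: what to expect

The compounds below may be only part of what the source reports. "The series", "measured", "known", "first", "only" and "open" are said of these compounds alone.

Compound 1 `CC(=O)N1CCC[C@H]1C(=O)N1CCC(NS(=O)(=O)c2cc(S(=O)(=O)c3ccccc3)ccc2C(F)(F)F)CC1` gives 12500 nM 
Compound 2 `CCNC(=O)N1CCC[C@H]1C(=O)N1CCC(NS(=O)(=O)c2cc(S(=O)(=O)c3ccccc3)ccc2C(F)(F)F)CC1` gives 100000 nM 
Compound 3 `O=C([C@@H]1CCCN1C(=O)Nc1ccccc1)N1CCC(NS(=O)(=O)c2cc(S(=O)(=O)c3ccccc3)ccc2C(F)(F)F)CC1` gives 25000 nM 

These three compounds share one core and differ only in the carbonyl-linked group on the amine nitrogen of the five-membered ring. In a physicochemical assay for solubility (a lower number here means a less soluble compound, a higher number a more soluble compound), compound 3 gives 25000 nM in the middle of the three numbers, which cannot be separated from compound 1 but is clearly lower than compound 2.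

Compound 4 `O=C([C@@H]1CCCN1Cc1ccccc1)N1CCC(NS(=O)(=O)c2cc(S(=O)(=O)c3ccccc3)ccc2C(F)(F)F)CC1` differs from compound 3 by one change, benzyl in place of phenylcarbamoyl on an amine nitrogen in a ring here. Going by the values given here, the measured steps at this nitrogen are the only guide. Two go beyond the scatter and are modest in size, namely an 8.0-fold higher number from compound 1 to compound 2 (0.90 log units; beyond the scatter) and a 4.0-fold lower number from compound 2 to compound 3 (0.60 log units; beyond the scatter) in turn, while a 2.0-fold higher number from compound 1 to compound 3 (0.30 log units; within the scatter) stays within it. Among the compounds with values here, all three compounds keep a carbonyl on that nitrogen and compound 4 has none, so no measured step matches this change and the direction is open. The expected outcome in this assay is therefore no clear shift, with an estimated 1.3-fold lower number from compound 3 to compound 4 (0.10 log units; within the scatter) as the central guess. For compound 4 the estimated value is 20000 nM with an expected range from 5000 nM to 80000 nM as its span.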

Compound 4, solubility: 25000 nM
Compound 4: middle estimate off by 1.3-fold (0.10 log units), on the low side, and the stated range covers the measured number.
By their numbers in this assay, from the lowest: compounds 1, 3 and 4 (each within the scatter of the next); then compound 2.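

Compound 4 is the only one of the four with no carbonyl on the amine nitrogen in a ring, yet in this assay the swap from phenylcarbamoyl to benzyl gives no change at the digits printed from compound 3 to compound 4 (within the scatter) and so cannot be told apart from no shift at all. The carbonyl, the hydrogen-bond donor and the hydrogen-bond acceptor all leave with phenylcarbamoyl, so among these compounds their loss comes with no readable change in solubility. Benzyl also reads alongside acetyl, with a 2.0-fold higher number from compound 1 to compound 4 (0.30 log units; within the scatter) in the same assay, but apart from ethylcarbamoyl, with a 4.0-fold lower number from compound 2 to compound 4 (0.60 log units; beyond the scatter), which leaves compound 2 as the one compound that stands out, and no supporting data say why.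

As far as these compounds go, what remains open is whether that high reading belongs to the ethyl chain on the carbonyl, as a longer chain such as propyl or butyl in the same place could show. A plain ethyl group set directly on the ring nitrogen, or a benzyl group carrying an amine or a carboxylic acid, would test whether this position can move the number further without any carbonyl.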